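Lactam for Piperazine on a Shared Core: Cytotoxicity Outlook

A few compounds are considered here, and "the series" means these few. Any claim that something is new, unique, unknown or untested is made for them only; others in the source may bear on it.

Measured so far:
Compound 1, `Cc1cc(-c2ccc3[nH]ccc3c2)cn2c(CSCCc3ccccc3)cnc12`, reaches in an ADME assay on HEL cells (Homo sapiens) for cytotoxicity, with a stated time of 3 days (a higher number here means that more compound is tolerated, a lower number that less compound is tolerated), only a limit, >= 20 ug/mL.
Compound 2, `Cc1cc(-c2ccco2)cn2c(CSCCc3ccccc3)cnc12`, gives in this assay a limit as well, > 4 ug/mL.
Compound 3, `Cc1cc(N2CCN(C)CC2)cn2c(CSCCc3ccccc3)cnc12`, gives in this assay a number, 20 ug/mL.

Within the data shown here, compound 3 thus holds the only number in this set; the two other values are limits, the limit of > 4 ug/mL in this assay, at which 1 of the 3 values shown sits, and (the limit of >= 20 ug/mL in this assay, at which 1 of the 3 values shown sits). The steps into compound 3 are a number no higher from compound 1 to compound 3 (the limit leaves the size open) and a step that the limit leaves unreadable from compound 2 to compound 3, and the step that the two limits leave unreadable from compound 1 to compound 2 is likewise unreadable. Compound 4, `Cc1cc(N2CCCC2=O)cn2c(CSCCc3ccccc3)cnc12`, differs from compound 3 by 2-oxopyrrolidin-1-yl in place of 4-methylpiperazin-1-yl on an aromatic carbon. Among the measured compounds shown here, no measured step in this assay involves the 2-oxopyrrolidin-1-yl group, and the steps that touch the 4-methylpiperazin-1-yl group are unreadable; they give no direction. Compound 4 is expected to sit close to compound 3 in this assay. The expected step is no change at the digits printed from compound 3 to compound 4 (within the scatter), within the scatter. The estimate for compound 4 in this assay is 20 ug/mL, with a range from 8 ug/mL to 50 ug/mL.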

Compound 4, minimum cytotoxic concentration: > 100 ug/mL
Compound 4 ended at the assay's limit; the forecaster's own chance of this, stated with the estimate: 50%; at least 5.0-fold (0.69 log units) between middle value and limit.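

In this assay compound 4 gives > 100 ug/mL, which is a limit of the assay and not a number. With 2-oxopyrrolidin-1-yl in place of 4-methylpiperazin-1-yl on this aromatic carbon, the set gains its first readable step at this position, an at least 5.0-fold higher number from compound 3 to compound 4 (0.69 log units; beyond the scatter), so what stands here can shift the tolerated concentration beyond the scatter. The steps from compound 1 and from compound 2 to compound 4 cannot be read, so the lactam cannot be ranked against the indolyl or furanyl compounds.

The compounds shown leave open how far the tolerated concentration of compound 4 extends, and whether the step follows the carbonyl, the ring size or the loss of the methylated ring nitrogen. Going by these compounds, how a morpholin-4-yl group or an open-chain amide on the same carbon would compare also stays open.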